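A few compounds are considered here, and "the series" means these few. Any claim that something is new, unique, unknown or untested is made for them only; others in the source may bear on it.

Three compounds sharing one core have been examined in an ADME assay on L02 cells (Homo sapiens) for cytotoxicity, read by MTT assay, with a stated time of 48 h; on this read-out lower numbers stand for stronger inhibition and higher numbers for weaker inhibition. Compound 1 `O=C1O[C@@H](CO)CN1c1ccc(-n2cc(-c3ccccn3)cn2)c(F)c1` gives 59 ug/mL. Compound 3 `CCN1CCN(C[C@H]2CN(c3ccc(-n4cc(-c5ccccn5)cn4)c(F)c3)C(=O)O2)CC1` gives 99 ug/mL. For compound 2 `CN(CCC#N)C[C@H]1CN(c2ccc(-n3cc(-c4ccccn4)cn3)c(F)c2)C(=O)O1` the assay reports only a limit, > 400 ug/mL, so compound 2 stands at the top of the numbers shown, as the limit of > 400 ug/mL in this assay, at which 1 of the 3 values shown sits, records. The change from compound 1 gave an at least 6.7-fold higher number from compound 1 to compound 2 (0.83 log units; beyond the scatter), whereas a 1.7-fold higher number from compound 1 to compound 3 (0.22 log units; within the scatter). Compound 4 `O=C1O[C@@H](CN2CCC(O)CC2)CN1c1ccc(-n2cc(-c3ccccn3)cn2)c(F)c1` differs from compound 2 by 4-hydroxypiperidin-1-yl in place of (2-cyanoethyl)(methyl)amino on a saturated chain carbon bound to a saturated ring carbon. The step bearing on it most closely is an at least 4.0-fold lower number from compound 2 to compound 3 (0.60 log units; beyond the scatter), where a ring amine also replaced the open-chain amine. A lowering beyond the scatter is therefore expected, an at least 2.6-fold lower number from compound 2 to compound 4 (0.42 log units; beyond the scatter), and compound 4 is estimated at 150 ug/mL, between 60 ug/mL and 400 ug/mL.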

Compound 4, half-maximal inhibitory concentration: > 400 ug/mL
Compound 4: only a limit was reported (the forecaster's own chance of this, stated with the estimate: 25%); middle value at least 2.6-fold (0.42 log units) away from the limit.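

In this assay, a ring amine on this saturated chain carbon does not by itself lower the number: compound 4 stands at a limit, as compound 2 does, so the step between them cannot be read: the limit of > 400 ug/mL in this assay, at which 2 of the 4 values shown sit.

Among the ring amines the group matters, with an at least 4.0-fold higher number from compound 3 to compound 4 (0.60 log units; beyond the scatter) when 4-hydroxypiperidin-1-yl takes the place of 4-ethylpiperazin-1-yl. Set against the hydroxy group, the same change gives an at least 6.7-fold higher number from compound 1 to compound 4 (0.83 log units; beyond the scatter).

Where compound 2 and compound 4 truly lie remains open. So does whether the second ring nitrogen of compound 3 or its ethyl group accounts for its lower number, which morpholin-4-yl or 4-methylpiperazin-1-yl at this place would help to separate.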